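Swapping the Sulfur Substituent on a Low-Inhibition Analogue

The source may hold more compounds than are shown below. What is called first, only, known or untested is meant among the compounds shown, and "the series" means these compounds.

Compound 1 `O=c1c2cn(C3COC3)nc2nc(SCc2cccc(F)c2)n1-c1ccccc1` and compound 3 `CC(Sc1nc2nn(C3COC3)cc2c(=O)n1-c1ccccc1)c1cccnc1` share one version of the core, while compound 2 `Cn1ncc2c(=O)n(-c3ccccc3)c(SCc3cccc(F)c3)nc21` and the not yet measured compound 4 `CC(Sc1nc2c(cnn2C)c(=O)n1-c1ccccc1)c1cccnc1` share another. In an assay on PEO1 cells for inhibition of Retinaldehyde dehydrogenase 3 (Homo sapiens), read by flow cytometry, with a stated time of 30 min, tested at 1 uM (a higher number here means more inhibition at the concentration tested (going by the name of the read-out), a lower number less inhibition), compound 1 gives 50% and compound 3 gives 99%. Compound 2 gives 3%, the lowest of the three numbers: compound 1 lies nearest to it and compound 3 furthest from it, and both gaps are beyond the scatter.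

Compound 4 differs from compound 2 in a single place: 1-(pyridin-3-yl)ethyl in place of 3-fluorobenzyl on a sulfur. The same exchange has been measured once, on the other version of the core, and there it gave a number 49 percentage points higher from compound 1 to compound 3 (beyond the scatter). For the measured compounds named here, that one step is the only guide available. A rise of similar size is therefore expected here, with the caution that one comparison cannot show whether both versions of the core respond alike, and that compound 2 starts far lower than compound 1 did. For compound 4 an upward step of about a number 47 percentage points higher from compound 2 to compound 4 (beyond the scatter) is expected. Compound 4 is estimated at 50% in this assay, within a range from 15% to 85%.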

Compound 4, a percentage reported as inhibition, at one concentration (the size of the read-out at that concentration, not a potency) in the Retinaldehyde dehydrogenase 3 assay: 95%
Compound 4: the middle estimate sits 45 percentage points below what was measured; the measured number lies above the stated range.
By their numbers in the Retinaldehyde dehydrogenase 3 assay, from the lowest: compound 2; then compound 1; then compounds 4 and 3 (each within the scatter of the next).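

In the Retinaldehyde dehydrogenase 3 assay, 1-(pyridin-3-yl)ethyl in place of 3-fluorobenzyl on a sulfur gives a number 92 percentage points higher from compound 2 to compound 4 (beyond the scatter), so the rise seen on the core of compound 1 also appears on a second core, though the two steps differ in size: the same change on two cores in the Retinaldehyde dehydrogenase 3 assay, a number 49 percentage points higher (beyond the scatter) from compound 1 to compound 3 and a number 92 percentage points higher (beyond the scatter) from compound 2 to compound 4, 43 percentage points apart, beyond the scatter of two such steps

In a physicochemical assay for solubility, using the shake flask method, in phosphate buffer, with a stated time of 24 h, at pH 7.4 (on this read-out higher numbers stand for higher solubility and lower numbers for lower solubility), compound 2 gives < 700 nM, and this is a limit of the assay, not a number. In the physicochemical assay compound 4 gives 209000 nM, which shows that the same exchange on a sulfur brings a large gain in solubility as well as in inhibition: the measured solubility of compound 2, < 700 nM, and of compound 4, 209000 nM, an at least 290-fold higher number (2.47 log units; beyond the scatter)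

This exchange alters the aromatic ring and the attachment to the sulfur together, so the compounds shown cannot tell whether the ring nitrogen or the ethyl branch carries either step. Also open is how a longer chain on the sulfur, or an amine on the aromatic ring, would behave in these two assays, and whether the change would hold on any core beyond the two shown.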